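Chloro in place of methyl: cytotoxicity expected to stay at the limit

The source may hold more compounds than are shown below. What is called first, only, known or untested is meant among the compounds shown, and "the series" means these compounds.

Compound 1 `COc1ccc(NC(=O)c2cccc(/C=C3\CC(=O)N(c4ccccc4)C3=O)c2)c(C)c1` in an ADME assay on SW480 cells (Homo sapiens) for cytotoxicity, read by MTT assay, with a stated time of 72 h (a lower number here means a stronger inhibitor, a higher number a weaker inhibitor), gives > 100000 nM, a limit.
Compound 2 `O=C(Nc1ccccc1)c1cccc(/C=C2\CC(=O)N(c3ccccc3)C2=O)c1` in this assay gives > 100000 nM, a limit.
Compound 3 `Cc1ccc(NC(=O)c2cccc(/C=C3\CC(=O)N(c4ccccc4)C3=O)c2)cc1` in this assay gives > 100000 nM, a limit.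

Compound 3 thus stands at the same limit as the other two measured compounds, and nothing in the numbers ranks it among them. Compound 4 `O=C(Nc1ccc(Cl)cc1)c1cccc(/C=C2\CC(=O)N(c3ccccc3)C2=O)c1` differs from it by chloro in place of methyl on an aromatic carbon. The measured steps bear on this change only loosely: a step that the two limits leave unreadable from compound 2 to compound 3, a step that the two limits leave unreadable from compound 1 to compound 2 and a step that the two limits leave unreadable from compound 1 to compound 3 are all unreadable, since every value sits at the limit of > 100000 nM in this assay, at which 3 of the 3 values shown sit. No direction can be taken from them, so the expectation for the step from compound 3 to compound 4 is none beyond the scatter, most likely again a limit rather than a number. Compound 4 is estimated at 150000 nM (from 60000 nM to 500000 nM), which is a step that the limit leaves unreadable from compound 3 to compound 4.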

Compound 4, half-maximal inhibitory concentration: > 100000 nM
Compound 4 was reported as a limit; the forecaster's own chance of this, stated with the estimate: 85%; the middle value lies beyond the limit too.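

Compound 4 adds no readable step: its steps from compound 1, compound 2 and compound 3 cannot be read, because all four compounds share one limit: the limit of > 100000 nM in this assay, at which 4 of the 4 values shown sit. The compounds shown leave open whether this assay responds at all to a change of group at this place.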